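A few compounds are considered here, and "the series" means these few. Any claim that something is new, unique, unknown or untested is made for them only; others in the source may bear on it.

Of the compounds shown here, two built on one shared core have so far been measured in an assay on MDA-MB-231 cells for binding affinity to C-X-C chemokine receptor type 4 (Homo sapiens), read by immunofluorescence and microscopy, with stated times of 10 min and 30 min; on this read-out higher numbers stand for an effect only at larger amounts of compound and lower numbers for an effect already at smaller amounts. Compound 1 `O=C(NCc1ccc(CNS(=O)(=O)c2ccccc2)cc1)c1cccc(F)c1` gives 100 nM in this assay. Compound 2 `Cc1ccc(S(=O)(=O)NCc2ccc(CNC(=O)c3ccccc3)cc2)cc1` did not yield an exact number: in this assay compound 2 gives > 1000 nM, and this is a limit of the assay rather than a measured value, namely (the limit of > 1000 nM in this assay, at which 1 of the 2 values shown sits). Compound 2 therefore stands at the weaker edge of what the two values show, with no precise figure behind it.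

Compound 3 `Cc1ccc(S(=O)(=O)NCc2ccc(CNC(=O)c3ccc([N+](=O)[O-])cc3)cc2)cc1` has not yet been measured. It differs from compound 2 in one place only: nitro in place of hydrogen on an aromatic carbon. Within the data shown here, since the value of compound 2 is only a limit, the step to compound 3 has no fixed starting point, and nothing among the measured compounds shows how a nitro group behaves on this core. The step in this assay from compound 2 to compound 3 is expected to be a step that the limit leaves unreadable from compound 2 to compound 3, that is, nothing beyond the scatter. Compound 3 is accordingly expected to give about 1500 nM in this assay, somewhere between 300 nM and 10000 nM, with a real chance that only another limit is reported.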

Compound 3, effective concentration (reported as EC, without a stated level of effect): 10 nM
Compound 3: middle estimate off by 150-fold (2.18 log units), on the high side; measured number below the stated range.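

In this assay, the change from phenyl to 4-nitrophenyl gives an at least 100-fold lower number from compound 2 to compound 3 (2.00 log units; beyond the scatter), so a single substitution at this aromatic carbon, para to a large group, can shift the number far beyond the scatter. Compound 2 on its own gave no sign that this carbon mattered, and its value is a limit, not a number. The printed size of the step is therefore only the smallest it can be, and the true step could be larger, as it is anchored on a limit: the limit of > 1000 nM in this assay, at which 1 of the 3 values shown sits.

On these data alone, it remains open whether an amine, a nitrile or a carboxylic acid on the same carbon would lower the number as well, or whether the nitro group would do the same on another carbon of this ring. With a single substituent at a single place, these compounds also cannot say which feature of the nitro group goes with the change, or whether the same swap would have a similar effect on a compound without the methyl group of compound 2.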